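The source may hold more compounds than are shown below. What is called first, only, known or untested is meant among the compounds shown, and "the series" means these compounds.

Compound 2 `O=C(COc1ccc2c(=O)ccoc2c1)Nc1cccc(NC(=O)c2ccccc2)c1` sets the reference point here. In an assay on isolated protein for inhibition of Rho-associated protein kinase 2 (Homo sapiens), read by scintillation counting, radiometric assay and 33P incorporation, with a stated time of 40 min, in the presence of a further agent that is not named here (a lower number here means a stronger inhibitor, a higher number a weaker inhibitor), compound 2 gives 16 nM, the lowest of the three numbers measured. Its nearest neighbour is compound 3 `Cc1cc(C(=O)Nc2cccc(NC(=O)COc3ccc4c(=O)ccoc4c3)c2)ccc1C(F)(F)F`, which gives 43 nM in this assay, and the furthest is compound 1 `COc1ccc(OCC(=O)Nc2cccc(NC(=O)c3ccc(N(C)C)cc3)c2)cc1F`, which gives 652 nM in this assay. Compound 4 `Cc1cc(C(=O)Nc2cccc(NC(=O)COc3ccc4c(=O)ccoc4c3)c2)no1` differs from compound 2 in one place: 5-methyl-1,2-oxazol-3-yl in place of phenyl on a carbonyl carbon.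

For the measured compounds named here, the one measured step at the same place is a 2.7-fold higher number from compound 2 to compound 3 (0.43 log units; beyond the scatter), a modest rise from a change on the carbonyl carbon. Going by the values given here, compound 1 shares no single-point step with compound 2 and its number only marks the wide spread of the set. Among the compounds with values here, no measured pair shows a five-membered ring with two hetero atoms replacing phenyl, so the direction for compound 4 is uncertain; a small loss of potency, within or just beyond the scatter, is the expected outcome. The step from compound 2 to compound 4 is estimated as a 2.2-fold higher number from compound 2 to compound 4 (0.34 log units; beyond the scatter). Compound 4 is therefore expected to give 35 nM in this assay, within a range from 12 nM to 110 nM.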

Compound 4, half-maximal inhibitory concentration: 5 nM
Estimate against measurement, compound 4: 7.0-fold (0.85 log units) above, outside the stated range (below it).
By their numbers in this assay, from the lowest: compound 4; then compound 2; then compound 3; then compound 1.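

In this assay, for the compounds shown here, the place on a carbonyl carbon whose other neighbour is an amide-type nitrogen proves able to give a lower number as well as a higher one: 5-methyl-1,2-oxazol-3-yl in place of phenyl gives (a 3.2-fold lower number from compound 2 to compound 4 (0.51 log units; beyond the scatter)), whereas the only earlier step here went up. The contrast is larger against the group carried by compound 3 (an 8.6-fold lower number from compound 3 to compound 4 (0.93 log units; beyond the scatter)), so a six-membered aromatic ring of carbon only is not required at this place. Nothing measured here accounts for the gain.

The compounds shown do not separate the contribution of the five-membered ring from that of its methyl group, which a plain 1,2-oxazol-3-yl would address. On these data alone, how a pyridine ring or an amine at this place would compare also remains open.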